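The source may report more compounds than this note shows. Statements on the series, on what has been measured and on what is new or still open speak of the compounds shown alone.

Within the data shown here, in an ADME assay on HepG2 2.2.15 cells (Homo sapiens) for cytotoxicity (on this read-out lower numbers stand for higher toxicity in this test and higher numbers for lower toxicity in this test), compound 1 `CCOCC(=O)OCCc1c(-c2ccccc2Cl)c2cc(Cl)ccc2[nH]c1=O` gives 130000 nM, the second highest of the three numbers measured so far. Compound 2 `O=C(OCCc1c(-c2ccccc2Cl)c2cc(Cl)ccc2[nH]c1=O)c1ccco1` gives 98000 nM, and compound 3 `O=C(/C=C/c1ccccc1)OCCc1c(-c2ccccc2Cl)c2cc(Cl)ccc2[nH]c1=O` gives 230000 nM. Compound 4 `COc1ccc(/C=C/C(=O)OCCc2c(-c3ccccc3Cl)c3cc(Cl)ccc3[nH]c2=O)cc1` has not yet been tested; it differs from compound 1 in that (2-(4-methoxyphenyl)ethenyl in place of ethoxymethyl on a carbonyl carbon). The measured step that bears most closely on this change is a 1.8-fold higher number from compound 1 to compound 3 (0.25 log units; within the scatter), where a related 2-phenylethenyl group replaced ethoxymethyl on a carbonyl carbon; a 2.3-fold higher number from compound 2 to compound 3 (0.37 log units; beyond the scatter) points the same way. Since compound 4 carries a group of the same kind, a step of similar size and direction is expected: a 1.5-fold higher number from compound 1 to compound 4 (0.19 log units; within the scatter). Compound 4 is therefore estimated at 200000 nM, with a likely range from 100000 nM to 400000 nM.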

Compound 4, half-maximal cytotoxic concentration: > 1200000 nM
Compound 4 was reported as a limit; the forecaster's own chance of this, stated with the estimate: 20%; middle value at least 6.0-fold (0.77 log units) away from the limit.
By their numbers in this assay, from the lowest: compounds 2, 1 and 3 (each within the scatter of the next, the first and the last beyond it). At a limit, above all of these: compound 4.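

In this assay compound 4 gives > 1200000 nM, which is a limit of the assay and not a number. Among these compounds, a single methoxy in place of hydrogen on an aromatic carbon gives an at least 5.2-fold higher number from compound 3 to compound 4 (0.71 log units; beyond the scatter), so this small change moves the read-out further than any step among the earlier compounds. The whole 2-(4-methoxyphenyl)ethenyl group gives an at least 9.2-fold higher number from compound 1 to compound 4 (0.96 log units; beyond the scatter) and an at least 12-fold higher number from compound 2 to compound 4 (1.08 log units; beyond the scatter). The compounds shown leave open whether a hydroxy group or an amine in place of that methoxy would give a similar step. From the compounds shown here alone, how far the true value of compound 4 lies past its limit also stays open.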